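This account rests on a few compounds, and the source may have more. Where it says the series, first, only, none or still open, it means among the compounds named here.

Working notes on the series. Compound 1 `OC[C@H]1O[C@@H](n2cnc3c(NCc4cccc(F)c4)ncnc32)[C@H](O)[C@@H]1O` gives 15300 nM in a functional assay on MCF cells (Homo sapiens) for antiproliferative activity, with a stated time of 72 h; on this read-out lower numbers stand for stronger inhibition and higher numbers for weaker inhibition. Compound 2 `OC[C@H]1O[C@@H](n2cnc3c(NCc4ccccc4Cl)ncnc32)[C@H](O)[C@@H]1O` reaches only a limit of this assay, > 166000 nM. Compound 3 `OC[C@H]1O[C@@H](n2cnc3c(NCc4cccc(Br)c4)ncnc32)[C@H](O)[C@@H]1O` likewise stands at a limit, > 166000 nM. Compound 3 thus stands apart from compound 1, with an at least 10-fold higher number from compound 1 to compound 3 (1.03 log units; beyond the scatter), and compound 2 shows the same picture with an at least 10-fold higher number from compound 1 to compound 2 (1.03 log units; beyond the scatter); between the two limits, a step that the two limits leave unreadable from compound 2 to compound 3. Two of the three values shown sit at the same limit (the limit of > 166000 nM in this assay, at which 2 of the 3 values shown sit).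

Compound 4 `OC[C@H]1O[C@@H](n2cnc3c(NCc4ccc(F)cc4Cl)ncnc32)[C@H](O)[C@@H]1O` is not yet measured and differs from compound 3 by 2-chloro-4-fluorophenyl in place of 3-bromophenyl on a saturated chain carbon bound to a nitrogen on an aromatic ring. Going by the values given here, the steps that bear on it are the two large ones leaving compound 1, both beyond the scatter, and the unreadable one between the two limits. Both halogenated phenyl groups closest to the new one (the 2-chlorophenyl of compound 2 and the 3-bromophenyl of compound 3) sit at the limit, so no return toward the value of compound 1 is expected; a limit is again the most likely report. Compound 4 is expected to give 170000 nM, in the range 40000 nM to 600000 nM. The step expected is a step that the limit leaves unreadable from compound 3 to compound 4, within the scatter.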

Compound 4, half-maximal inhibitory concentration: > 166000 nM
Compound 4 ended at the assay's limit (the forecaster's own chance of this, stated with the estimate: 70%); the middle value does not contradict the limit.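

In this assay, the exchange of one halogenated phenyl group for another gives an at least 10-fold higher number from compound 1 to compound 4 (1.03 log units; beyond the scatter), so a fluoro on the phenyl ring does not by itself keep the value of compound 1. Fluoro in place of hydrogen on an aromatic carbon also brings no visible return from compound 2: compound 2, compound 3 and compound 4 all stand at a limit, and the steps among them cannot be read. The limit now dominates the compounds shown: the limit of > 166000 nM in this assay, at which 3 of the 4 values shown sit.

Going by these compounds alone, compound 1 gives 15300 nM, the only value shown that is not a limit. Still open, on these data alone, are how far activity depends on the 3-fluorophenyl group itself and whether a phenyl carrying an amine or a carboxylic acid, or a longer chain to the phenyl ring, would give a value below the limit.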